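Replacing the propylcarbamoyl group on the shared core

The source may report more compounds than this note shows. Statements on the series, on what has been measured and on what is new or still open speak of the compounds shown alone.

Compound 2 `CCCNC(=O)c1ccc(-c2nn(Cc3ccccc3)c3ccccc23)cc1` has been measured in a functional assay on cells (Platelet, Homo sapiens) for inhibition (a lower number here means a stronger inhibitor, a higher number a weaker inhibitor), where compound 2 gives only a limit, > 10000 nM. Compound 1 `NC(=O)c1ccc(-c2nn(Cc3ccccc3)c3ccccc23)cc1` likewise gives a limit in this assay, > 10000 nM. Among the compounds with values here, the single step between them, a step that the two limits leave unreadable from compound 1 to compound 2, therefore cannot be read in size, as the limit of > 10000 nM in this assay, at which 2 of the 2 values shown sit, shows. Compound 3 `CO/N=C\c1ccc(-c2nn(Cc3ccccc3)c3ccccc23)cc1` differs from compound 2 by a group of 4 heavy atoms (2 carbon, 1 nitrogen, 1 oxygen; no ring) in place of a group of 6 heavy atoms (4 carbon, 1 nitrogen, 1 oxygen; no ring), on an aromatic carbon. Within the data shown here, no measured step bears on this change, so no shift beyond the scatter can be expected in this assay in either direction. Compound 3 is therefore expected to stay near the limit, at about 15000 nM with a range from 3000 nM to 60000 nM, a step that the limit leaves unreadable from compound 2 to compound 3.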

Compound 3, half-maximal inhibitory concentration: > 10000 nM
Compound 3: a limit, no number; the forecaster's own chance of this, stated with the estimate: 80%; the middle value lies beyond the limit too.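

Within the data shown here, compound 1, compound 2 and compound 3 all give only limits in this assay, so no step among them can be read: the limit of > 10000 nM in this assay, at which 3 of the 3 values shown sit. The compounds shown leave open which change to the shared core, if any, would give a readable value in this assay.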